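The source may report more compounds than this note shows. Statements on the series, on what has been measured and on what is new or still open speak of the compounds shown alone.

In a functional assay on NCI-H460 cells (Homo sapiens) for cytotoxicity, read by MTT assay, with a stated time of 24 h (a lower number here means a stronger inhibitor, a higher number a weaker inhibitor), three compounds have been measured so far. Compound 1 `C=CCn1c(=O)c(C=O)cc2ccccc21` reports only a limit, > 100000 nM. Compound 2 `C#CCn1c(=O)c(C=O)cc2ccccc21` also reports only a limit, > 100000 nM. These two share (the limit of > 100000 nM in this assay, at which 2 of the 3 values shown sit). Among the compounds with values here, compound 3 `C#CCn1c(=O)c(/C=C/C(=O)/C=C(O)/C=C/c2ccc(O)c(OC)c2)cc2ccccc21` gives 25400 nM, which makes it the only compound in the set with an actual number rather than a limit, so its standing rests on that single reading.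

Compound 4 `C#CCn1c(=O)c(/C=C/C(=O)/C=C(O)/C=C/c2ccc(O)c(OC)c2)cc2cc(C)ccc21` departs from compound 3 by one change, methyl in place of hydrogen on an aromatic carbon. Within the data shown here, the one measured step available, a step that the two limits leave unreadable from compound 1 to compound 2, places ethynyl in place of vinyl on a saturated chain carbon bound to an aromatic nitrogen. That is a different kind of change at a different place, and its size cannot be read, so it offers no guide to the methyl. Among the measured compounds shown here, no measured step bears directly on this change, and no shift beyond the usual scatter is expected in this assay, in either direction. The expected change is a 1.1-fold lower number from compound 3 to compound 4 (0.02 log units; within the scatter). For compound 4 the estimated value is 24000 nM, with an expected range of 10000 nM to 60000 nM.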

Compound 4, half-maximal inhibitory concentration: 21800 nM
Estimate against measurement, compound 4: 1.1-fold (0.04 log units) above; the measured number falls inside the stated range.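

In this assay, methyl in place of hydrogen on this aromatic carbon, meta to a fused ring and para to a fused ring, gives a 1.2-fold lower number from compound 3 to compound 4 (0.07 log units; within the scatter), so at this place in the shared core the swap leaves the reading where it was, as far as this assay can tell. This is the first step in the set that can be read, and it shows that a change to the core can be followed on the long unsaturated side chain that compound 3 and compound 4 share; the only earlier step, from compound 1 to compound 2, cannot be read, and each of those two compounds reports only a limit: the limit of > 100000 nM in this assay, at which 2 of the 4 values shown sit.

The same holds for this one pair and this one group only, and it offers no explanation for the absence of a shift. From the compounds shown here alone, whether a larger or different group on this carbon, such as ethyl, methoxy, chlorine, an amine or a carboxylic acid, would move the number remains open, as does whether methyl on another aromatic carbon of the core would behave the same way.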